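The compounds below may be only part of what the source reports. "The series", "measured", "known", "first", "only" and "open" are said of these compounds alone.

In a functional assay on HCT-116 cells (Homo sapiens) for inhibition, read by sulforhodamine B assay, with a stated time of 48 h (on this read-out lower numbers stand for stronger inhibition and higher numbers for weaker inhibition), compound 1 (`COc1ccc(C(O)(Cc2ccc(C)cc2)c2cccc3ccccc23)c(OC)c1OC`) gives > 20000 nM, which is a limit of the assay. Compound 3 (`COc1ccc(C(O)(Cc2ccc(F)cc2)c2cccc3ccccc23)c(OC)c1OC`) gives > 20000 nM, also a limit, so where it stands is known only as a limit. Going by the values given here, both compounds sit at that same limit (the limit of > 20000 nM in this assay, at which 2 of the 3 values shown sit), and the one measured step, a step that the two limits leave unreadable from compound 1 to compound 3, offers no size to carry forward. Among the compounds with values here, compound 2 (`CCOC(=O)CO/N=C(/c1ccc(OC)c(OC)c1OC)c1cccc2ccccc12`), which carries an ethoxycarbonyl group, gives 3360 nM, the only true number in this set. Compound 4 (`CCOC(=O)C(C)C(O)(c1ccc(OC)c(OC)c1OC)c1cccc2ccccc12`) puts 1-(ethoxycarbonyl)ethyl in place of 4-fluorobenzyl on a saturated chain carbon bound to two aromatic carbons and an oxygen on a saturated carbon. Within the data shown here, the only guide to this change is compound 2 at 3360 nM, which shares the ethoxycarbonyl group but differs elsewhere, so the guide is a weak one. Inhibition is therefore expected to strengthen, although the assay may again report only a limit. The expected step is an at least 2.2-fold lower number from compound 3 to compound 4 (0.34 log units; beyond the scatter), and its size is uncertain. For compound 4 the estimated value is 9000 nM, with an expected range from 3000 nM to 20000 nM.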

Compound 4, half-maximal inhibitory concentration: > 20000 nM
Compound 4: a limit, no number (the forecaster's own chance of this, stated with the estimate: 40%); middle value at least 2.2-fold (0.34 log units) from the limit.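

In this assay compound 4 sits at a limit, as compound 1 and compound 3 do, so no step among these three can be read: the limit of > 20000 nM in this assay, at which 3 of the 4 values shown sit. The compounds shown leave open whether 1-(ethoxycarbonyl)ethyl in place of 4-fluorobenzyl changes inhibition at all, and by how much.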